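The source may hold more compounds than are shown below. What is called first, only, known or untested is meant among the compounds shown, and "the series" means these compounds.

Measured in a functional assay on MCF7 cells (Homo sapiens) for cytotoxicity, read by MTT assay, with a stated time of 24 h; on this read-out lower numbers stand for stronger inhibition and higher numbers for weaker inhibition:
- compound 1 `CCNc1cc(-c2ccc(NC(=O)Nc3ccc(C)cc3)cc2C)ccn1` gives 9210 nM
- compound 2 `CCNc1cc(-c2ccc(NC(=O)Nc3cccc(Cl)c3)cc2C)ccn1` gives 4180 nM
- compound 3 `CCNc1cc(-c2ccc(NC(=O)Nc3ccc(C(F)(F)F)cc3)cc2C)ccn1` gives 6870 nM

Compound 1 has the highest of these three numbers; compound 3 sits within the scatter of it, while compound 2 lies beyond, with a 2.2-fold lower number from compound 1 to compound 2 (0.34 log units; beyond the scatter). Compound 4 `CCNc1cc(-c2ccc(NC(=O)Nc3ccccc3Cl)cc2C)ccn1` is not yet measured. Its difference from compound 1 is 2-chlorophenyl in place of 4-methylphenyl on an amide-type nitrogen. Among the measured compounds shown here, the one measured step that bears on this is the chlorophenyl step from compound 1 to compound 2, which lowered the number modestly; compound 3 shows a change within the scatter. By analogy a modest lowering is expected, a 1.7-fold lower number from compound 1 to compound 4 (0.22 log units; within the scatter), though the chlorine sits elsewhere on the ring, so the expectation is loose. Compound 4 is estimated at 5500 nM, with a range from 2800 nM to 11000 nM.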

Compound 4, half-maximal inhibitory concentration: 8350 nM
For compound 4 the middle estimate is 1.5-fold (0.18 log units) below the measured one; low and high end bracket the measured number.
By their numbers in this assay, from the lowest: compounds 2, 3, 4 and 1 (each within the scatter of the next, the first and the last beyond it).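

In this assay 2-chlorophenyl on this amide-type nitrogen gives a 1.1-fold lower number from compound 1 to compound 4 (0.04 log units; within the scatter) and so, unlike the 3-chlorophenyl of compound 2, does not separate from 4-methylphenyl beyond the scatter. The other two steps, a 1.2-fold higher number from compound 3 to compound 4 (0.08 log units; within the scatter) and a 2.0-fold higher number from compound 2 to compound 4 (0.30 log units; within the scatter), also stay within the scatter, so the two chlorophenyl groups cannot be told apart here. Nothing available explains these numbers. From the compounds shown here alone, what remains open is whether an amine or a carboxylic acid in place of the chlorine would leave the number within the scatter of these four compounds.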